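Adding a nitro group to a pair of non-toxic compounds

The compounds below may be only part of what the source reports. "The series", "measured", "known", "first", "only" and "open" are said of these compounds alone.

Compound 1 `COC(=O)Cn1cc(COc2ccc3c(C)cc(=O)oc3c2)nn1` gives > 100 ug/mL in an ADME assay on Huh-7 cells (Homo sapiens) for cytotoxicity, read by MTT assay, with a stated time of 72 h (on this read-out lower numbers stand for higher toxicity in this test and higher numbers for lower toxicity in this test), a limit of the assay rather than a number.
Compound 2 `Cc1cc(=O)oc2cc(OCc3cn(Cc4ccccc4)nn3)ccc12` gives > 100 ug/mL in this assay, likewise a limit.

Compound 2 therefore stands at the limit of > 100 ug/mL in this assay, at which 2 of the 2 values shown sit. Among the compounds with values here, the one measured step, a step that the two limits leave unreadable from compound 1 to compound 2, cannot be sized. The change to compound 3 `Cc1cc(=O)oc2cc(OCc3cn(Cc4ccc([N+](=O)[O-])cc4)nn3)ccc12` is nitro in place of hydrogen on an aromatic carbon. Within the data shown here, no measured step bears on this change, so no direction is expected beyond the scatter, and compound 3 is expected to stay near the same limit, the step of a number no higher from compound 2 to compound 3 (the limit leaves the size open) being only an estimate. Compound 3 is estimated at 100 ug/mL, within 50 ug/mL to 200 ug/mL.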

Compound 3, half-maximal cytotoxic concentration: > 100 ug/mL
Compound 3 was reported as a limit (the forecaster's own chance of this, stated with the estimate: 70%); the middle value lies on the limit itself.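

Within the data shown here, no step among compound 1, compound 2 and compound 3 can be read, since all three stand at a limit: the limit of > 100 ug/mL in this assay, at which 3 of the 3 values shown sit.

The compounds shown leave open at what concentration in this assay any of them would become toxic, and whether the nitro group of compound 3 makes any difference.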